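Working notes: nitro in place of fluoro, compound 4

This account rests on a few compounds, and the source may have more. Where it says the series, first, only, none or still open, it means among the compounds named here.

Values in a physicochemical assay for solubility, at pH 7.4; a lower number here means a less soluble compound, a higher number a more soluble compound:
- compound 1 `Cc1cc(NC(=O)Nc2ccccc2N)c2ccccc2n1`: 51800 nM
- compound 2 `Cc1cc(NC(=O)Nc2ccccc2C(N)=O)c2ccccc2n1`: 200 nM
- compound 3 `Cc1cc(NC(=O)Nc2ccccc2F)c2ccccc2n1`: 3800 nM

In this assay, compound 3 is second highest of the three numbers, at 3800 nM. Compound 1 lies above it and compound 2 below it.

The next structure is compound 4 `Cc1cc(NC(=O)Nc2ccccc2[N+](=O)[O-])c2ccccc2n1`, not yet measured. It carries nitro in place of fluoro on an aromatic carbon, ortho to a large group.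

Three measured steps exchange the group on this aromatic carbon: a 260-fold lower number from compound 1 to compound 2 (2.41 log units; beyond the scatter), a 14-fold lower number from compound 1 to compound 3 (1.13 log units; beyond the scatter) and a 19-fold higher number from compound 2 to compound 3 (1.28 log units; beyond the scatter). All three are large and beyond the scatter, so a change here has moved the number strongly in both directions. None of them involves nitro, so the direction for compound 4 rests on weak evidence. The nearest guide is compound 2 at 200 nM, since carbamoyl is the measured group closest in build to nitro.

A moderate fall is therefore expected, smaller than the measured steps, and the expected change is a 3.2-fold lower number from compound 3 to compound 4 (0.50 log units; beyond the scatter). For compound 4 the estimate is 1200 nM, with an expected range of 250 nM to 5000 nM.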

Compound 4, solubility: 200 nM
The estimate for compound 4 lay 6.0-fold (0.78 log units) above the measured number, outside the stated range (below it).
By their numbers in this assay, from the lowest: compounds 2 and 4 (each within the scatter of the next); then compound 3; then compound 1.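

In this assay, nitro in place of fluoro on this aromatic carbon gives a 19-fold lower number from compound 3 to compound 4 (1.28 log units; beyond the scatter), so fluoro no longer stands alone above the carbamoyl compound: a second replacement of it also ends far lower. Among these compounds, the comparison with carbamoyl gives no change at the digits printed from compound 2 to compound 4 (within the scatter), which places two different groups at one level on the shared core, and this level is the lowest seen at this position so far. Among the compounds shown here, the comparison with amino gives a 260-fold lower number from compound 1 to compound 4 (2.41 log units; beyond the scatter), which matches the widest gap and leaves amino as the only group at the top, with its steps to all three others beyond the scatter.

No measurement accompanies these numbers that could explain why the groups fall in this order. From the compounds shown here alone, it remains open whether a methoxy group, a carboxylic acid or a dimethylamino group on the same aromatic carbon would join amino at the top, stay with fluoro or fall to the level shared by nitro and carbamoyl, and whether the same order of groups would hold on another carbon of this ring.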